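The compounds below may be only part of what the source reports. "The series", "measured", "known", "first", "only" and "open" are said of these compounds alone.

Measured in a functional assay on MCF7 cells (Homo sapiens) for cytotoxicity, read by MTT assay, with a stated time of 48 h; on this read-out higher numbers stand for weaker inhibition and lower numbers for stronger inhibition:
compound 1 `COc1ccc(/C=N/NC(=O)CSc2nnc(-c3ccncc3)o2)cc1` gives 17600 nM;
compound 2 `O=C(CSc1nnc(-c2ccncc2)o1)N/N=C/c1ccccc1[N+](=O)[O-]` gives 35600 nM;
compound 3 `O=C(CSc1nnc(-c2ccncc2)o1)N/N=C/c1cc(Cl)cc(Cl)c1O` gives 5920 nM.

Compound 3 stands lowest of the three numbers, that is, it is the strongest inhibitor among them; the steps of a 3.0-fold lower number from compound 1 to compound 3 (0.47 log units; beyond the scatter) and a 6.0-fold lower number from compound 2 to compound 3 (0.78 log units; beyond the scatter) both lie beyond the scatter, so its place is secure.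

Compound 4 `COc1cc(/C=N/NC(=O)CSc2nnc(-c3ccncc3)o2)ccc1O` has not yet been measured. It differs from compound 3 in one place: 4-hydroxy-3-methoxyphenyl in place of 3,5-dichloro-2-hydroxyphenyl on a carbon with a double bond to nitrogen. Among the measured compounds shown here, two measured steps bear on this change: a 3.0-fold lower number from compound 1 to compound 3 (0.47 log units; beyond the scatter) and a 6.0-fold lower number from compound 2 to compound 3 (0.78 log units; beyond the scatter). Both of them bring the 3,5-dichloro-2-hydroxyphenyl group in, and both lower the number. Compound 4 takes that group away again, which points toward a higher number. For the measured compounds named here, its new group carries a methoxy, as compound 1 does, and a hydroxyl, as compound 3 does; no measured step isolates the hydroxyl alone, so the size is uncertain. A modest rise, landing between the values of compound 3 and compound 1, is expected: a 1.9-fold higher number from compound 3 to compound 4 (0.27 log units; within the scatter). For compound 4 in this assay, the expected value is 11000 nM, with a range from 5000 nM to 28000 nM.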

Compound 4, half-maximal inhibitory concentration: 3780 nM
The estimate for compound 4 lay 2.9-fold (0.46 log units) above the measured number; measured number below the stated range.
By their numbers in this assay, from the lowest: compounds 4 and 3 (each within the scatter of the next); then compound 1; then compound 2.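

In this assay the step of a 1.6-fold lower number from compound 3 to compound 4 (0.19 log units; within the scatter) shows that the two chlorines of the 3,5-dichloro-2-hydroxyphenyl group are not required for a low number on this carbon with a double bond to nitrogen: the 4-hydroxy-3-methoxyphenyl group, which carries no chlorine, cannot be told apart from it on this read-out. The same group stands clearly apart from the two rings without a hydroxyl, with a 4.7-fold lower number from compound 1 to compound 4 (0.67 log units; beyond the scatter) and a 9.4-fold lower number from compound 2 to compound 4 (0.97 log units; beyond the scatter) as its steps, so among these four compounds the two with a hydroxyl on the ring give the two lowest numbers, and none of the four goes against this. Nothing measured on these compounds gives a reason for this pattern.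

Among the compounds shown here, no pair here differs by the hydroxyl alone, so its own share in these steps stays open, as the hydroxyl compounds also differ from the others in their further groups. In this assay, going by these compounds, it also remains open how a phenyl ring carrying an amine or a carboxylic acid would read on this same carbon.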